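Urea series on the shared core: chloro to trifluoromethyl swap

The source may hold more compounds than are shown below. What is called first, only, known or untested is meant among the compounds shown, and "the series" means these compounds.

Compounds measured so far:
compound 1 `COc1cc(Cl)cc(-c2nn(-c3cccc(NC(=O)Nc4ccc(Cl)c(C(F)(F)F)c4)c3)cc2-c2ccncc2)c1` — 2.57%
compound 2 `COc1cc(Cl)cc(-c2nn(-c3cccc(NC(=O)Nc4ccc(Cl)c(Cl)c4)c3)cc2-c2ccncc2)c1` — 4.66%

In a functional assay on MCF7 cells (Homo sapiens) for inhibition, read by sulforhodamine B assay, with a stated time of 48 h, tested at 10 uM (on this read-out higher numbers stand for a weaker effect at the one concentration tested and lower numbers for a stronger effect), compound 1 gives 2.57% and compound 2 gives 4.66%. For the measured compounds named here, the only step known is a number 2.1 percentage points higher from compound 1 to compound 2 (within the scatter). Compound 2 stands as the higher of the two numbers, though its gap to compound 1 is within the scatter.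

Compound 3 `COc1cc(Cl)cc(-c2nn(-c3cccc(NC(=O)Nc4cccc(C(F)(F)F)c4)c3)cc2-c2ccncc2)c1` differs from compound 2 by 3-(trifluoromethyl)phenyl in place of 3,4-dichlorophenyl on an amide-type nitrogen. Going by the values given here, no measured step covers this change; the one step known is small and within the scatter. A modest shift toward weaker effect is expected, a number 4.3 percentage points higher from compound 2 to compound 3 (within the scatter), still near the scatter. Compound 3 is estimated at 9% with a range of 1% to 30%.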

Compound 3, a percentage reported as activity, at one concentration (the size of the read-out at that concentration, not a potency): 0.3%
Compound 3: the middle estimate sits 8.7 percentage points above what was measured, outside the stated range (below it).
By their numbers in this assay, from the lowest: compounds 3, 1 and 2 (each within the scatter of the next).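

In this assay, hydrogen in place of chloro on an aromatic carbon gives a number 2.3 percentage points lower from compound 1 to compound 3 (within the scatter) and 3-(trifluoromethyl)phenyl in place of 3,4-dichlorophenyl on an amide-type nitrogen gives a number 4.4 percentage points lower from compound 2 to compound 3 (within the scatter), so neither change separates the compounds. The chloro of compound 1 is thus not required to keep the read-out in this low range at the one concentration tested. Nothing available explains this tolerance.

From the compounds shown here alone, how an amine or a carboxylic acid in place of trifluoromethyl would read remains open. A single concentration also leaves open whether these three compounds would differ in the size of their effect at any other concentration.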